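A few compounds are considered here, and "the series" means these few. Any claim that something is new, unique, unknown or untested is made for them only; others in the source may bear on it.

The series shares a core with a pyridin-3-yl group on a fused bicyclic system, varied at the ring substituent and at the ring nitrogen. Among the measured compounds shown here, compound 1 `FC(F)(F)c1ccc2c(c1)nc(-c1cccnc1)n2C1CC1` carries a trifluoromethyl group and a cyclopropyl on the nitrogen; in an assay on V79 cells for inhibition of cytochrome P450 11B1, mitochondrial (Homo sapiens), read by HTRF, with a stated time of 1 h (on this read-out lower numbers stand for stronger inhibition and higher numbers for weaker inhibition), compound 1 reaches only a limit, > 10000 nM, so no number is known for it, and it is the one value sitting at the limit described in the limit of > 10000 nM in this assay, at which 1 of the 3 values shown sits. Compound 2 `Clc1ccc2nc(-c3cccnc3)n(C3CC3)c2c1` carries chloro in place of the trifluoromethyl and keeps the cyclopropyl; in this assay compound 2 gives 477 nM. Compound 3 `Cn1c(-c2cccnc2)nc2ccc(F)cc21` carries fluoro and a methyl on the nitrogen; in this assay compound 3 gives 677 nM, which lies within the usual scatter of the number for compound 2. Among the two numbers recorded, compound 2 and compound 3 cannot be told apart.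

Compound 4 `Fc1ccc2nc(-c3cccnc3)n(C3CC3)c2c1` has not yet been measured in this assay. It differs from compound 2 by fluoro in place of chloro on an aromatic carbon. For the measured compounds named here, no measured pair isolates this exchange. Given that compound 3, which also carries fluoro, gives 677 nM, the step from compound 2 to compound 4 is expected to be small and, if anything, toward a higher number, a 1.5-fold higher number from compound 2 to compound 4 (0.17 log units; within the scatter). Compound 4 is accordingly expected at about 700 nM, between 300 nM and 1800 nM.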

Compound 4, half-maximal inhibitory concentration: 401 nM
Beside the measured number, compound 4's estimate is 1.7-fold (0.24 log units) above it, and the stated range covers the measured number.
By their numbers in this assay, from the lowest: compounds 4, 2 and 3 (each within the scatter of the next). At a limit, above all of these: compound 1.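

Among the compounds shown here, compound 4 supplies the first pair in which only the halogen on this aromatic carbon changes, and in this assay fluoro in place of chloro gives a 1.2-fold lower number from compound 2 to compound 4 (0.08 log units; within the scatter), so the two halogens cannot be told apart at this place on the ring. For the compounds shown here, it also supplies the first pair that isolates the group on the aromatic nitrogen with fluoro held constant, and cyclopropyl in place of methyl gives a 1.7-fold lower number from compound 3 to compound 4 (0.23 log units; within the scatter), so this exchange does not separate the two compounds either. Neither step goes beyond the scatter, and no measurement shown offers a reason for either one.

The compounds shown leave open whether a group of another kind on this aromatic carbon, such as a methoxy group, an amine or a carboxylic acid, would move the number beyond the scatter, since only chloro and fluoro form a matched pair here. They also leave open whether a longer chain on the aromatic nitrogen, such as butyl, would separate itself from methyl and cyclopropyl in this assay.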